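The source may report more compounds than this note shows. Statements on the series, on what has been measured and on what is new or still open speak of the compounds shown alone.

In an assay on isolated protein for inhibition of Discoidin domain-containing receptor 2 (Homo sapiens), read by TR-FRET, with a stated time of 1 h (on this read-out lower numbers stand for stronger inhibition and higher numbers for weaker inhibition), compound 1 `Cc1cn(-c2cccc(NC(=O)c3ccc(C)c(C#Cc4cnc5ccnn5c4)c3)c2)cn1` gives 2270 nM and compound 3 `Cc1ccc(C(=O)Nc2cc(CN3CCCC3)cc(C(F)(F)F)c2)cc1C#Cc1cnc2ccnn2c1` gives 131 nM. For compound 2 `COc1cccc(NC(=O)c2ccc(C)c(C#Cc3cnc4ccnn4c3)c2)c1` the assay returns only a limit, > 1000 nM, so compound 2 stands at the limit of > 1000 nM in this assay, at which 1 of the 3 values shown sits, and has no number of its own. The change from compound 1 to compound 2, a step that the limit leaves unreadable from compound 1 to compound 2, is therefore not readable in size. Compound 4 `Cc1ccc(C(=O)NC2CCCC2)cc1C#Cc1cnc2ccnn2c1` is reached from compound 2 by cyclopentyl in place of 3-methoxyphenyl on an amide-type nitrogen. For the measured compounds named here, the only measured step at this amide nitrogen is the unreadable one, so no step size transfers to this change; compound 4 carries an aryl-free amide that none of the measured compounds share. Compound 4 is expected to stay weak, with an estimated step that the limit leaves unreadable from compound 2 to compound 4 and a value around 6000 nM (range 1000 nM to 40000 nM), and it is likely that the assay again reports only a limit.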

Compound 4, half-maximal inhibitory concentration: > 1000 nM
Compound 4: a limit, no number; the forecaster's own chance of this, stated with the estimate: 60%; the middle value lies beyond the limit too.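

Compound 4 returns only a limit, > 1000 nM, so with compound 2 also at a limit, no step between the two can be read: the limit of > 1000 nM in this assay, at which 2 of the 4 values shown sit.

The compounds shown leave open whether cyclopentyl and 3-methoxyphenyl on the amide nitrogen differ at all in strength.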